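The source may report more compounds than this note shows. Statements on the series, on what has been measured and on what is new or still open speak of the compounds shown alone.

Measured compounds:
compound 1 `CCOC(=O)c1cn(C[C@H]2O[C@@H](n3ccc(=O)[nH]c3=O)[C@H](SCC)[C@@H]2SCC)nn1`: >= 100000 nM
compound 2 `CCS[C@@H]1[C@H](SCC)[C@@H](Cn2cc(-c3ccc(OC)cc3)nn2)O[C@H]1n1cc(C)c(=O)[nH]c1=O`: 66000 nM

Both were tested in a functional assay on HeLa cells (Homo sapiens) for cytotoxicity, read by MTT assay, with a stated time of 72 h; on this read-out higher numbers stand for an effect only at larger amounts of compound and lower numbers for an effect already at smaller amounts. For compound 1 the value is a limit of the assay rather than a number. Compound 2 therefore gives the only number shown, and the one other value sits at the limit of >= 100000 nM in this assay, at which 1 of the 2 values shown sits; on this scale compound 2 acts only at a large amount of compound.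

Compound 3 `CCOC(=O)c1cn(C[C@H]2O[C@@H](n3cc(C)c(=O)[nH]c3=O)[C@H](SCC)[C@@H]2SCC)nn1` has not been tested. Compared with compound 2, the change is ethoxycarbonyl in place of 4-methoxyphenyl on an aromatic carbon, with everything else the same. Within the data shown here, since no step between measured compounds is available, the size of the step cannot be read from measured pairs. The values at hand point to weak activity throughout, so the expectation is that compound 3 stays at a similarly high concentration, with a change from compound 2 to compound 3 of about a 1.5-fold higher number from compound 2 to compound 3 (0.18 log units; within the scatter), which is not beyond the usual scatter. Compound 3 is expected to give about 100000 nM, between 40000 nM and 300000 nM, with a real chance that only a limit is reported.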

Compound 3, half-maximal effective concentration: >= 100000 nM
Compound 3 ended at the assay's limit; the forecaster's own chance of this, stated with the estimate: 55%; the middle value lies on the limit itself.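

Among these compounds, on the aromatic carbon of the five-membered aromatic ring with 3 nitrogen, ethoxycarbonyl in place of 4-methoxyphenyl gives the first readable step in this assay: an at least 1.5-fold higher number from compound 2 to compound 3 (0.18 log units; that floor lies within the scatter). The value of compound 3 is a limit of the assay and not a number, so this step is only a floor, and that floor does not go beyond the usual scatter. This swap shows no sign of a stronger effect on the cells, the step for methyl in place of hydrogen between compound 1 and compound 3 cannot be read, and the set now gathers at one point: the limit of >= 100000 nM in this assay, at which 2 of the 3 values shown sit.

Going by these compounds, how far compound 3 truly lies from compound 2 stays open. Also open, on these data alone, is whether another group on this carbon, such as an amine, a carboxylic acid or a longer alkyl chain, would act at smaller amounts.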